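The source may report more compounds than this note shows. Statements on the series, on what has been measured and on what is new or still open speak of the compounds shown alone.

Measured so far:
- compound 1 `CCCCCCCCCCCCCCCCCc1nnc(S)o1` gives 0.143 uM
- compound 2 `CC/C=C\C/C=C\C/C=C\CCCCCCCc1nnc(S)o1` gives 0.149 uM
- compound 3 `CC/C=C\C/C=C\C/C=C\CCCCCCCc1nnc(S)n1N` gives 0.264 uM

These three numbers all come from a functional assay on A549 cells (Homo sapiens) for cytotoxicity, read by sulforhodamine B assay (a lower number here means that less compound is tolerated, a higher number that more compound is tolerated), and lie within the usual scatter of repeated measurements of one another. Compound 1 therefore cannot be told apart from compound 2 or compound 3 on these data.

The compound still to be measured is compound 4 `CCCCCCCCCCCCCCCCCc1nnc(S)n1N`, which differs from compound 1 as follows: 4-amino-5-sulfanyl-4H-1,2,4-triazol-3-yl in place of 5-sulfanyl-1,3,4-oxadiazol-2-yl on a saturated chain carbon bound to a saturated chain carbon. In words, 4-amino-5-sulfanyl-4H-1,2,4-triazol-3-yl stands in place of 5-sulfanyl-1,3,4-oxadiazol-2-yl on a saturated chain carbon bound to a saturated chain carbon.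

Among the measured compounds shown here, only one measured step makes this same exchange, on a chain that contains double-bonded carbons: a 1.8-fold higher number from compound 2 to compound 3 (0.25 log units; within the scatter). That single step stayed within the scatter, and the data do not show whether it carries over to the chain of compound 1. Even so, it is the best available guide, so a small upward shift, and none beyond the scatter, is expected in this assay.

The step is estimated as a 1.5-fold higher number from compound 1 to compound 4 (0.19 log units; within the scatter) and is expected to be of similar size.

For compound 4 the expected value is 0.22 uM, with an estimated range from 0.11 uM to 0.45 uM as the measurement is awaited.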

Compound 4, half-maximal toxic concentration: 0.282 uM
Beside the measured number, compound 4's estimate is 1.3-fold (0.11 log units) below it; measured number inside the range.
By their numbers in this assay, from the lowest: compounds 1, 2, 3 and 4 (each within the scatter of the next).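

On the saturated chain, putting 4-amino-5-sulfanyl-4H-1,2,4-triazol-3-yl in place of 5-sulfanyl-1,3,4-oxadiazol-2-yl gives a 2.0-fold higher number from compound 1 to compound 4 (0.29 log units; within the scatter) in this assay. Until now this exchange had been read only on a chain with double-bonded carbons, and it has now been read on a chain without them, with steps of matching size: the same change on two cores in this assay, a 1.8-fold higher number (0.25 log units; within the scatter) from compound 2 to compound 3 and a 2.0-fold higher number (0.29 log units; within the scatter) from compound 1 to compound 4, 1.1-fold (0.05 log units) apart, within the scatter of two such steps. On both chains, then, the two ring groups cannot be told apart in this assay, and the added amino group and the change of ring atoms that come with the exchange leave the number within the scatter.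

The compounds shown leave open whether a different group at this place, such as a carboxylic acid or a simple amine in place of the ring, would move the number beyond the scatter. They also leave open whether a much shorter chain carrying either ring would keep the number in this range, and whether the two ring groups would remain indistinguishable on such a chain.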